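Kinetic solubility notes on compound 4 and its neighbours

This account rests on a few compounds, and the source may have more. Where it says the series, first, only, none or still open, it means among the compounds named here.

Measured so far:
- compound 1 `Cc1oc(-c2ccccc2Cl)nc1CN1CCC(C(=O)NCCCN2C[C@H](C)C[C@H](C)C2)CC1`: > 72 ug/mL
- compound 2 `Cc1cccc(Cl)c1-c1nc(CN2CCC(C(=O)NCCCN3CCC(C(C)C)CC3)CC2)c(C)o1`: > 76 ug/mL
- compound 3 `Cc1ccccc1-c1nc(CN2CCC(C(=O)N3CCN(CCN(C)C)CC3)CC2)c(C)o1`: > 67 ug/mL

All three readings in a physicochemical assay for solubility, in phosphate buffer, measured as kinetic solubility, at pH 7.4 (on this read-out higher numbers stand for higher solubility and lower numbers for lower solubility), are limits of the assay, not numbers. For compound 1 the reading > 72 ug/mL is a limit, as recorded in the limit of > 72 ug/mL in this assay, at which 1 of the 3 values shown sits. For compound 2 the reading > 76 ug/mL is likewise a limit, see (the limit of > 76 ug/mL in this assay, at which 1 of the 3 values shown sits). For compound 3 the reading > 67 ug/mL is also a limit, see (the limit of > 67 ug/mL in this assay, at which 1 of the 3 values shown sits). Among the compounds with values here, compound 1 therefore stands at the upper bound of what this assay reports, and since every measured compound sits at a limit, no step between measured compounds can be counted and no ordering among the three follows.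

Compound 4 `Cc1ccc(-c2nc(CN3CCC(C(=O)NCCCN4C[C@H](C)C[C@H](C)C4)CC3)c(C)o2)cc1C` has not yet been measured in this assay. It differs from compound 1 in one place: 3,4-dimethylphenyl in place of 2-chlorophenyl on an aromatic carbon.

Within the data shown here, with no measured step available, the step that the limit leaves unreadable from compound 1 to compound 4 is expected to be none beyond the scatter, and compound 4 is expected most likely to come back as a limit again. For compound 4 the estimate in this assay is 75 ug/mL, with a range of 30 ug/mL to 150 ug/mL.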

Compound 4, solubility: > 71 ug/mL
Compound 4 was reported as a limit; the forecaster's own chance of this, stated with the estimate: 60%; the middle value does not contradict the limit.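

Within the data shown here, with compound 1 and compound 4 both reported as limits in this assay, no step between the two can be read. The compounds shown leave open whether 3,4-dimethylphenyl in place of 2-chlorophenyl changes the read-out at all, and how any of the four compounds ranks against the others.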